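The compounds below may be only part of what the source reports. "The series", "measured", "known", "first", "only" and "open" are said of these compounds alone.

Working notes on a diaryl urea series carrying a shared core.

Of the compounds shown here, three have been measured in a functional assay on A549 cells (Homo sapiens) for inhibition, read by MTT assay, with a stated time of 48 h; on this read-out higher numbers stand for weaker inhibition and lower numbers for stronger inhibition. Compound 1 `COc1cccc(NC(=O)Nc2cccc(-c3cccc4[nH]nc(N)c34)c2)c1` gives 2490 nM in this assay. Compound 2 `Nc1n[nH]c2cccc(-c3cccc(NC(=O)Nc4ccc(Cl)c(C(F)(F)F)c4)c3)c12` gives 3410 nM, and compound 3 `Nc1n[nH]c2cccc(-c3cccc(NC(=O)Nc4cc(C(F)(F)F)cc(C(F)(F)F)c4)c3)c12` gives 1510 nM. On these numbers compound 1 stands second highest of three, but its gap to compound 2 and its gap to compound 3 both lie within the scatter, so no ordering among the three can be claimed; all three sit in the same low-micromolar band.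

The next compound, compound 4 `CC(C)c1cccc(NC(=O)Nc2cccc(-c3cccc4[nH]nc(N)c34)c2)c1`, differs from compound 1 in one place: isopropyl in place of methoxy on an aromatic carbon. The change is a swap of one small group for another on the terminal aromatic ring of the urea, with no ring gained or lost.

For the measured compounds named here, nothing in the measured set pairs two compounds that differ by a single change, so the size of this step has no precedent here. Given that the three measured compounds, with different substituents on that ring, all fall within the scatter of one another in this assay, the step from compound 1 to compound 4 is expected to be small and within the scatter, a 1.2-fold lower number from compound 1 to compound 4 (0.07 log units; within the scatter), with no direction favoured. Compound 4 is accordingly estimated at 2100 nM in this assay, with a range from 900 nM to 5000 nM.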

Compound 4, half-maximal inhibitory concentration: 1420 nM
Compound 4: the middle estimate sits 1.5-fold (0.17 log units) above what was measured, within the range that was stated.
By their numbers in this assay, from the lowest: compounds 4, 3, 1 and 2 (each within the scatter of the next, the first and the last beyond it).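

For the compounds shown here, this is the first step that can be read at a single place: in this assay, isopropyl in place of methoxy on the terminal aromatic ring, meta to a large group, gives a 1.8-fold lower number from compound 1 to compound 4 (0.24 log units; within the scatter). The 3-methoxyphenyl to 3-isopropylphenyl change therefore swaps an oxygen-bearing group for an all-carbon one at this position without a step beyond the scatter, so the oxygen of the methoxy group is not shown to matter for this read-out. No measurement bearing on why this step is as small as it is stands available for this change.

Going by these compounds, whether a group of another kind at this position, such as an amine, a carboxylic acid or a longer chain, would give a step beyond the scatter stays open. Also open, on these data alone, is whether the same change would read alike on a terminal ring carrying a second substituent, as in compound 2 and compound 3.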